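This account rests on a few compounds, and the source may have more. Where it says the series, first, only, none or still open, it means among the compounds named here.

Measured so far:
compound 1 `NCCn1ncc2c(NCc3ccccc3[N+](=O)[O-])cc(C(F)(F)F)cc21`
compound 2 `O=[N+]([O-])c1ccccc1CNc1cc(C(F)(F)F)cc2[nH]ncc12`

In an assay for inhibition of Indoleamine 2,3-dioxygenase 1 (Homo sapiens), with stated times of 10 min and 60 min (a higher number here means a weaker inhibitor, a lower number a stronger inhibitor), compound 1 gives only a limit, > 100000 nM. In this assay, within the data shown here, compound 2 gives 14000 nM, the only number so far. The other value recorded, that of compound 1, is a limit: the limit of > 100000 nM in this assay, at which 1 of the 2 values shown sits. Among the measured compounds shown here, the one measured step, an at least 7.1-fold lower number from compound 1 to compound 2 (0.85 log units; beyond the scatter), changes a substituent on an aromatic nitrogen, a site that is untouched in the next compound. Compound 3 `O=[N+]([O-])c1ccccc1CNc1cc(Br)cc2[nH]ncc12` differs from compound 2 by bromo in place of trifluoromethyl on an aromatic carbon. For the measured compounds named here, no measured step bears on this change, so for compound 3 no step beyond the scatter is expected, no change at the digits printed from compound 2 to compound 3 (within the scatter). Compound 3 is estimated at 14000 nM, within 4000 nM to 50000 nM.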

Compound 3, half-maximal inhibitory concentration: 8040 nM
The estimate for compound 3 lay 1.7-fold (0.24 log units) above the measured number; the range from low to high includes it.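

In this assay, bromo in place of trifluoromethyl on an aromatic carbon gives a 1.7-fold lower number from compound 2 to compound 3 (0.24 log units; within the scatter). This position therefore accepts either the single bromine atom or the four heavy atoms of trifluoromethyl without a difference that can be read, at least for this pair. Nothing shown bears on a cause for this step.

From the compounds shown here alone, what an amine, a methoxy group or a carboxylic acid on this same carbon would give remains open. Also open, going by these compounds, is whether methyl on the aromatic nitrogen would give a number or a limit, as 2-aminoethyl did.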